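A few compounds are considered here, and "the series" means these few. Any claim that something is new, unique, unknown or untested is made for them only; others in the source may bear on it.

Compound 1 `COc1ccc(CNC(=O)/C=C/c2coc3cc(O)ccc3c2=O)cc1` gives 10000 nM in a functional assay (QGY7701 cells, Homo sapiens) for inhibition, read by MTT assay, with a stated time of 48 h (on this read-out lower numbers stand for stronger inhibition and higher numbers for weaker inhibition), and compound 2 `O=C(/C=C/c1coc2cc(O)ccc2c1=O)NCc1ccccc1` gives 63000 nM, a change of a 6.3-fold higher number from compound 1 to compound 2 (0.80 log units; beyond the scatter). Compound 3 `O=C(/C=C/c1coc2cc(O)ccc2c1=O)NCc1ccc(F)cc1` is known only as a limit in this assay, reported as > 100000 nM; (the limit of > 100000 nM in this assay, at which 1 of the 3 values shown sits). The steps of an at least 10-fold higher number from compound 1 to compound 3 (1.00 log units; beyond the scatter) and an at least 1.5-fold higher number from compound 2 to compound 3 (0.20 log units; that floor lies within the scatter) leave compound 3 with no number of its own. Compound 4 `Cc1ccccc1NC(=O)/C=C/c1coc2cc(O)ccc2c1=O` differs from it by 2-methylphenyl in place of 4-fluorobenzyl on an amide-type nitrogen. Within the data shown here, no measured step covers this change: all three swap one group for another on an aromatic carbon, with modest shifts. The direction in this assay cannot be read from them, and a limit as the starting point widens the expectation further. Compound 4 is therefore estimated at 50000 nM, between 5000 nM and 200000 nM, an expected step of an at least 2.0-fold lower number from compound 3 to compound 4 (0.30 log units; that floor lies within the scatter).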

Compound 4, half-maximal inhibitory concentration: 9320 nM
Beside the measured number, compound 4's estimate is 5.4-fold (0.73 log units) above it; low and high end bracket the measured number.
By their numbers in this assay, from the lowest: compounds 4 and 1 (each within the scatter of the next); then compound 2. At a limit, above all of these: compound 3.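

Among these compounds, compound 4 is the first change on the amide-type nitrogen rather than on an aromatic carbon, and it shows that this position also moves the read-out in this assay, with 2-methylphenyl in place of benzyl giving a 6.8-fold lower number from compound 2 to compound 4 (0.83 log units; beyond the scatter). Compound 3 is known only as a limit, so an at least 10-fold lower number from compound 3 to compound 4 (1.03 log units; beyond the scatter) is a floor and not a measured size: the limit of > 100000 nM in this assay, at which 1 of the 4 values shown sits.

The compounds shown leave open whether the shift goes with the methyl group or with the change from benzyl to phenyl. They also leave open what an unsubstituted phenyl or a pyridyl group on that nitrogen would give.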